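This account rests on a few compounds, and the source may have more. Where it says the series, first, only, none or still open, it means among the compounds named here.

Measured in an ADME assay (liver) for metabolic stability, with Liver microsome (Homo sapiens) as the target, using microsomes and NADPH, with a stated time of 30 min, tested at 1 uM; on this read-out higher numbers stand for fast clearance and lower numbers for slow clearance:
- compound 1 `Nc1ccc(S(=O)(=O)N2CCN(c3ncc(C(O)(C(F)(F)F)C(F)(F)F)cc3C#CCO)CC2)cn1`: < 14 mL.min-1.g-1 (a limit of the assay)
- compound 2 `Nc1ccc(S(=O)(=O)N2CCN(c3ncc(C(O)(C(F)(F)F)C(F)(F)F)cc3-c3cccnc3)CC2)cn1`: 17 mL.min-1.g-1

Among the measured compounds shown here, compound 2 holds the only true number, 17 mL.min-1.g-1. Compound 3 `Nc1ccc(S(=O)(=O)N2CCN(c3ncc(C(O)(C(F)(F)F)C(F)(F)F)cc3-c3cnccc3F)CC2)cn1` differs from it in one place, pyridin-3-yl to 4-fluoropyridin-3-yl: fluoro in place of hydrogen on an aromatic carbon. For the measured compounds named here, the one measured step, an at least 1.2-fold higher number from compound 1 to compound 2 (0.08 log units; that floor lies within the scatter), starts from a limit and exchanges the whole group, so it gives no size for adding fluoro. No step beyond the scatter is therefore expected in this assay. The expected change is a 1.1-fold higher number from compound 2 to compound 3 (0.02 log units; within the scatter). For compound 3 the estimated value is 18 mL.min-1.g-1, with an expected range of 12 mL.min-1.g-1 to 32 mL.min-1.g-1.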

Compound 3, intrinsic clearance in microsomes: 17 mL.min-1.g-1
For compound 3 the middle estimate is 1.1-fold (0.02 log units) above the measured one, within the range that was stated.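

In this assay, fluoro on the aromatic carbon ortho to a large group and opposite the ring nitrogen gives no change at the digits printed from compound 2 to compound 3 (within the scatter), so this position accepts the atom without a readable shift in clearance. The exchange of the whole group reads an at least 1.2-fold higher number from compound 1 to compound 3 (0.08 log units; that floor lies within the scatter). That step starts from a limit of the assay, and only a floor can be read: the limit of < 14 mL.min-1.g-1 in this assay, at which 1 of the 3 values shown sits.

Going by these compounds, whether a methoxy group or an amine on this same carbon would move intrinsic clearance in microsomes beyond the scatter stays open.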